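A Bromo Substituent Added to Compound 3

A few compounds are considered here, and "the series" means these few. Any claim that something is new, unique, unknown or untested is made for them only; others in the source may bear on it.

Three members of the shared core have been measured. In a functional assay on MCF7 cells (Homo sapiens) for antiproliferative activity, read by MTT assay, with a stated time of 72 h (on this read-out higher numbers stand for weaker inhibition and lower numbers for stronger inhibition), compound 1 `O=C1NC(=S)S/C1=C\C1=Cc2ccccc2OC1` gives 68700 nM. Compound 2 `CCN1C(=O)S/C(=C\C2=Cc3ccccc3OC2)C1=O` reaches only a limit of this assay, > 200000 nM. Compound 3 `O=C(O)CN1C(=O)/C(=C/C2=Cc3ccccc3OC2)SC1=S` likewise gives only a limit, > 100000 nM, so its standing is a floor of weak inhibition rather than a number. Within the data shown here, the only single-point step, an at least 1.4-fold higher number from compound 1 to compound 3 (0.16 log units; that floor lies within the scatter), concerns the nitrogen substituent and is bounded by the limit of > 100000 nM in this assay, at which 1 of the 3 values shown sits. Compound 4 `O=C(O)CN1C(=O)/C(=C/C2=Cc3cc(Br)ccc3OC2)SC1=S` differs from compound 3 by bromo in place of hydrogen on an aromatic carbon. Among the measured compounds shown here, no measured step touches this aromatic position, so no shift beyond the scatter is expected, and the expected step that the limit leaves unreadable from compound 3 to compound 4 is flat. Compound 4 is therefore estimated at 150000 nM, within 60000 nM to 400000 nM, most likely reported again as a limit.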

Compound 4, half-maximal inhibitory concentration: > 25000 nM
Compound 4: no number, only a limit (the forecaster's own chance of this, stated with the estimate: 70%); the middle value does not contradict the limit.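

In this assay compound 3 gives only a limit, > 100000 nM. Among these compounds, compound 4 also gives only a limit, > 25000 nM, so no step between the two can be read. The compounds shown leave open what bromo in place of hydrogen does to this read-out.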